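A few compounds are considered here, and "the series" means these few. Any claim that something is new, unique, unknown or untested is made for them only; others in the source may bear on it.

Compound 1, `COC(=O)Nc1cc(-c2ccc(OC[C@@](C)(N)CC(C)C)cn2)ccn1`, gives 93% in an ADME assay on microsomes from liver (Mus musculus) for metabolic stability, read by LC-MS, using NADPH, with a stated time of 10 min, tested at 0.5 uM; on this read-out lower numbers stand for a less stable compound and higher numbers for a more stable compound.
Compound 2, `COC(=O)Nc1cc(-c2cnc(OC[C@@](C)(N)CC(C)C)c(Cl)c2)ccn1`, gives 65% in this assay.
Compound 3, `COC(=O)Nc1cc(-c2ccc(OC[C@@](C)(N)CC(C)C)nc2)ccn1`, gives 79% in this assay.

Compound 3 and compound 2 differ in one place only, (chloro in place of hydrogen on an aromatic carbon), and that step was a number 14 percentage points lower from compound 3 to compound 2 (beyond the scatter). Compound 1 and compound 3 are built from the same atoms joined differently; the difference between the two cores is not broken down here. Compound 4, `COC(=O)Nc1cc(-c2ccc(OC[C@@](C)(N)CC(C)C)c(Cl)n2)ccn1`, has not yet been measured in this assay. It differs from compound 1 by chloro in place of hydrogen on an aromatic carbon. This is the same kind of change as that between compound 3 and compound 2, not the same: in compound 4 the chloro is next to the ring nitrogen, whereas in compound 2 it is two atoms from the ring nitrogen. Among the compounds with values here, a step of similar size is expected from compound 1 because the single measured example is a number 14 percentage points lower from compound 3 to compound 2 (beyond the scatter), giving a number 15 percentage points lower from compound 1 to compound 4 (beyond the scatter). Compound 4 is therefore estimated at 78%, with a likely range from 62% to 92%.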

Compound 4, percent of the compound remaining: 72%
Estimate against measurement, compound 4: 6 percentage points above, within the range that was stated.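

Putting chloro in place of hydrogen on the core of compound 1 gave a number 21 percentage points lower from compound 1 to compound 4 (beyond the scatter) in this assay. The change therefore lowered the read-out on both cores, and the two steps cannot be told apart: the same change on two cores in this assay, a number 14 percentage points lower (beyond the scatter) from compound 3 to compound 2 and a number 21 percentage points lower (beyond the scatter) from compound 1 to compound 4, 7 percentage points apart, within the scatter of two such steps

Within the data shown here, this rests on only two pairs, with the chloro at a different place on each core, so it does not show that the step would hold on other cores, nor does it explain the drop. Still open, going by these compounds, is how another group at the same place as the chloro in compound 4, such as fluoro, methyl or a nitrile, would compare with hydrogen. Also open, on these data alone, is what a longer chain in place of the (2-amino-2,4-dimethylpentyl)oxy group would do.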